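Replacing a chlorophenyl with an aminophenyl on a pyrazole

The source may report more compounds than this note shows. Statements on the series, on what has been measured and on what is new or still open speak of the compounds shown alone.

Compound 1 `Cc1ccccc1-c1nn(-c2ccccc2Cl)cc1CNCCN1CCN(C)CC1` was tested in an ADME assay on Huh-7 cells (Homo sapiens) for cytotoxicity; on this read-out higher numbers stand for lower toxicity in this test and lower numbers for higher toxicity in this test. In this assay compound 1 reaches only the limit of the test, > 20000 nM, and no number within the measured range. This is where compound 1 stands: its result is a limit, and it is not alone there, since (the limit of > 20000 nM in this assay, at which 2 of the 3 values shown sit). Compound 2 `CCCN1CCC(CNCc2cn(-c3ccc(C(F)(F)F)cc3)nc2-c2ccc(Cl)cc2)CC1` gives a number in this assay, 1900 nM. Compound 3 `Cc1ccccc1-c1nn(-c2ccc(F)cc2F)cc1CNC1CCN(S(C)(=O)=O)CC1` again reaches only the limit of the test in this assay, > 20000 nM.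

The step of interest leads from compound 1 to compound 4 `Cc1ccccc1-c1nn(-c2ccc(N)cc2)cc1CNCCN1CCN(C)CC1`, which has not yet been measured in this assay. The change is 4-aminophenyl in place of 2-chlorophenyl on an aromatic nitrogen. No pair of measured compounds differing in one place is available to show how large such a change is in this assay, so the expectation rests on the two limits shown for compound 1 and compound 3. For compound 4 the expected step is a step that the limit leaves unreadable from compound 1 to compound 4, that is, nothing beyond the usual scatter. Compound 4 is therefore estimated to give 25000 nM in this assay, with a range from 8000 nM to 80000 nM, most likely reported again only as a limit.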

Compound 4, half-maximal cytotoxic concentration: > 20000 nM
Compound 4 gave a limit, no number; the forecaster's own chance of this, stated with the estimate: 70%; the middle value does not contradict the limit.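

Compound 4 gives only a limit in this assay, as compound 1 does, so putting 4-aminophenyl in place of 2-chlorophenyl has no readable size between these two compounds: the limit of > 20000 nM in this assay, at which 3 of the 4 values shown sit.

The compounds shown leave open whether this change alters the result in this assay at all, with neither compound having a number within the measured range.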